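The source may hold more compounds than are shown below. What is called first, only, known or untested is meant among the compounds shown, and "the series" means these compounds.

Measured compounds:
- compound 1, `O=C(O)CC[C@H](NC(=O)c1cc2ccccc2[nH]1)C(=O)N(C1CCCCC1)C1CCCCC1`: 59 nM
- compound 2, `CCCCCN(CCCCC)C(=O)C(CCC(=O)OCc1ccccc1)NC(=O)Nc1ccc(Cl)cc1`: 9300 nM

Both compounds were tested in an assay on isolated protein for inhibition of Cholecystokinin receptor type A (Rattus norvegicus); a higher number here means a weaker inhibitor, a lower number a stronger inhibitor. Compound 1 gives 59 nM, and compound 2 gives 9300 nM, which is the higher of the two numbers and stands well apart from the value of compound 1, beyond the usual scatter. The two compounds differ in more than one place, so nothing can be read from them about any single change.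

Compound 3, `CCCCCN(CCCCC)C(=O)C(CCC(=O)N1CCCC1)NC(=O)Nc1ccc(Cl)cc1`, has not yet been measured. It keeps the core of compound 2 and carries one change: pyrrolidin-1-yl in place of benzyloxy on a carbonyl carbon. Among the compounds with values here, no measured pair in this set shows the same change, so there is no step on which to lean for its size or direction. Within the data shown here, the only anchor is the value of compound 2 in this assay. Compound 3 is therefore expected to stay in the region of compound 2, with the step from compound 2 to compound 3 estimated as a 1.6-fold lower number from compound 2 to compound 3 (0.19 log units; within the scatter), a movement that may not exceed the scatter. On that basis compound 3 is estimated at 6000 nM, with a range from 1200 nM to 30000 nM.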

Compound 3, half-maximal inhibitory concentration: 680 nM
The estimate for compound 3 lay 8.8-fold (0.95 log units) above the measured number, and the stated range ends above it.
By their numbers in this assay, from the lowest: compound 1; then compound 3; then compound 2.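

In this assay, within the data shown here, the exchange of benzyloxy for pyrrolidin-1-yl on a carbonyl carbon gives a 14-fold lower number from compound 2 to compound 3 (1.14 log units; beyond the scatter) and is the first single change in this set that can be read. It shows that this place, on a carbonyl carbon whose other neighbour is a saturated chain carbon, is sensitive to what it carries, and that the six-membered aromatic ring of carbon only in benzyloxy is not needed for the number to fall. Several things change together in this one step, since the five-membered non-aromatic ring enters with fewer heavy atoms and a nitrogen takes the place of the oxygen on the carbonyl, and nothing available explains the size of the step.

The compounds shown leave open which of these differences carries the step. A dimethylamino group on the same carbonyl would test whether a ring is needed at all, and piperidin-1-yl or morpholin-4-yl would show how far the ring itself can be varied at this place.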